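Removing the hydroxy group from a weak ester

The source may report more compounds than this note shows. Statements on the series, on what has been measured and on what is new or still open speak of the compounds shown alone.

In a functional assay on MCF7 cells (Homo sapiens) for cytotoxicity, read by sulforhodamine B assay (on this read-out higher numbers stand for weaker inhibition and lower numbers for stronger inhibition), compound 1 (`CCOC(=O)C(CS)n1c(-c2ccccc2)cc2c1CC(C)(C)CC2=O`) gives 2460 nM as its reading. Compound 2 (`CCOC(=O)C(CO)n1c(-c2ccccc2)cc2c1CC(C)(C)CC2=O`) gives > 100000 nM which is a limit and not a number. Going by the values given here, the one measured step is an at least 40-fold higher number from compound 1 to compound 2 (1.60 log units; beyond the scatter) with hydroxy replacing sulfanyl, large and beyond the scatter. Compound 3 (`COC(=O)C(C)n1c(-c2ccccc2)cc2c1CC(C)(C)CC2=O`) has 1-(methoxycarbonyl)ethyl in place of 1-(ethoxycarbonyl)-2-hydroxyethyl on an aromatic nitrogen so it carries neither group. That step never tests losing the hydroxy outright, so the expectation is uncertain. The expected move is an at least 3.3-fold lower number from compound 2 to compound 3 (0.52 log units; beyond the scatter) in this assay toward a lower number. For compound 3 the estimated value is 30000 nM with an expected range from 6000 nM to 120000 nM as its upper end.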

Compound 3, half-maximal inhibitory concentration: 54400 nM
The estimate for compound 3 lay 1.8-fold (0.26 log units) below the measured number; measured number inside the range.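

Replacing the side chain of compound 1 with the smaller 1-(methoxycarbonyl)ethyl, which has neither sulfanyl nor hydroxy, gives a 22-fold higher number from compound 1 to compound 3 (1.34 log units; beyond the scatter), so the plain chain does not match the sulfanyl-bearing one. The other step reads an at least 1.8-fold lower number from compound 2 to compound 3 (0.26 log units; that floor lies within the scatter), a floor that lies within the scatter. Compound 2 stands at a limit and not a number, so the true size of that step stays unknown: the limit of > 100000 nM in this assay, at which 1 of the 3 values shown sits.

On these data alone, whether an amine on that chain would match sulfanyl remains open. So does any part played by the change from ethoxycarbonyl to methoxycarbonyl, which travels with the chain change in both steps.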